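The compounds below may be only part of what the source reports. "The series", "measured", "known", "first", "only" and "open" are said of these compounds alone.

Among the compounds with values here, in a functional assay on BV-2 cells (Mus musculus) for inhibition, read by Griess assay, with stated times of 1 h and 24 h (a higher number here means a weaker inhibitor, a lower number a stronger inhibitor), compound 3 `C=CCCC/C=C\CC#CC/C=C\C/C(I)=C\CCCC(=O)OC` gives 3100 nM, the lowest of the three numbers measured so far. Compound 1 `C=C/C=C/C/C(I)=C\CC#CC/C=C\C/C(I)=C\CCCC(=O)OC` gives 23300 nM, and compound 2 `C/C=C/CC/C(I)=C\CC#CC/C=C\C/C(I)=C\CCCC(=O)OC` gives 18000 nM. The next analogue, compound 4 `CCCCC/C=C\CC#CC/C=C\C/C(I)=C\CCCC(=O)OC`, differs from compound 3 by one small change: ethyl in place of vinyl on a saturated chain carbon, three bonds along the chain from a double-bonded chain carbon. In words, this is ethyl in place of vinyl on a saturated chain carbon, three bonds along the chain from a double-bonded chain carbon.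

Within the data shown here, no measured step makes this exact change. The two larger steps, a 7.5-fold lower number from compound 1 to compound 3 (0.88 log units; beyond the scatter) and a 5.8-fold lower number from compound 2 to compound 3 (0.76 log units; beyond the scatter), both remove an iodine-bearing group, which is not what happens here. The closest guide is a 1.3-fold lower number from compound 1 to compound 2 (0.11 log units; within the scatter), which also alters double bonds in a chain without removing iodine and stays within the scatter. On that single precedent, no shift beyond the scatter is expected, in either direction. The expected change is a 1.0-fold lower number from compound 3 to compound 4 (0.01 log units; within the scatter). Compound 4 is therefore estimated at 3000 nM, with an expected range of 1200 nM to 8000 nM.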

Compound 4, half-maximal inhibitory concentration: 1800 nM
The estimate for compound 4 lay 1.7-fold (0.22 log units) above the measured number; the range from low to high includes it.
By their numbers in this assay, from the lowest: compounds 4 and 3 (each within the scatter of the next); then compounds 2 and 1 (each within the scatter of the next).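

In this assay, ethyl in place of vinyl on a saturated chain carbon, three bonds along the chain from a double-bonded chain carbon, gives a step that stays small (a 1.7-fold lower number from compound 3 to compound 4 (0.24 log units; within the scatter)), so in this pair the double bond at this place can be lost without a shift beyond the scatter. The larger steps in this set are still those that take away the iodine-bearing group along with other parts of the chain (a 10-fold lower number from compound 2 to compound 4 (1.00 log units; beyond the scatter); a 13-fold lower number from compound 1 to compound 4 (1.11 log units; beyond the scatter)), and compound 4 shares with compound 3 the absence of that group. Nothing measured here explains why either change acts as it does.

As far as these compounds go, what an amine or a hydroxyl group would do in place of ethyl remains open. So does the effect of a longer chain at this place.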